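Changing the anilino aryl halogens on a shared core

This account rests on a few compounds, and the source may have more. Where it says the series, first, only, none or still open, it means among the compounds named here.

Measured in a functional assay on NCI-H1975 cells (Homo sapiens) for inhibition, read by MTT assay, with a stated time of 72 h; a higher number here means a weaker inhibitor, a lower number a stronger inhibitor:
Compound 1 `O=C(CSc1nc(Nc2ccccc2)c2ccccc2n1)Nc1ccccc1F` gives 9350 nM.
Compound 2 `O=C(CSc1nc(Nc2ccccc2)c2ccccc2n1)Nc1ccccc1Br` gives 10300 nM.
Compound 3 `C=CC(=O)Nc1cccc(NC(=O)CSc2nc(Nc3ccccc3Br)c3ccccc3n2)c1` gives 19300 nM.

Among these three, compound 3 sits apart from compound 1 by a gap that lies beyond the scatter, whereas its gap to compound 2 lies within the scatter, so compound 3 and compound 2 cannot be ordered against each other. Compound 4 `C=CC(=O)Nc1cccc(NC(=O)CSc2nc(Nc3ccc(F)c(Cl)c3)c3ccccc3n2)c1` is not yet measured. It differs from compound 3 in a single place: 3-chloro-4-fluorophenyl in place of 2-bromophenyl on a nitrogen on an aromatic ring.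

Among the measured compounds shown here, the only step that is known within this set, a 1.1-fold higher number from compound 1 to compound 2 (0.04 log units; within the scatter), concerns a halogen swap on the amide-side aryl ring, not on the anilino ring that changes here, and it lies within the scatter. For the measured compounds named here, no step among the measured compounds bears directly on the change from compound 3 to compound 4. For that reason no movement beyond the scatter is expected in this assay, and the estimated step is a 1.1-fold lower number from compound 3 to compound 4 (0.03 log units; within the scatter). Compound 4 is therefore expected to give about 18000 nM, with a range from 7000 nM to 45000 nM.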

Compound 4, half-maximal inhibitory concentration: > 50000 nM
Compound 4 ended at the assay's limit; the forecaster's own chance of this, stated with the estimate: 10%; middle value at least 2.7-fold (0.44 log units) away from the limit.
By their numbers in this assay, from the lowest: compounds 1, 2 and 3 (each within the scatter of the next, the first and the last beyond it). At a limit, above all of these: compound 4.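

In this assay, compound 4 gives > 50000 nM, and this value is a limit of the assay, not a number: the limit of > 50000 nM in this assay, at which 1 of the 4 values shown sits.

Putting 3-chloro-4-fluorophenyl in place of 2-bromophenyl on a nitrogen on an aromatic ring gives an at least 2.5-fold higher number from compound 3 to compound 4 (0.41 log units; beyond the scatter). This shows that the group at this position can move the reading beyond the scatter, which the halogen swap on the other aryl ring, a 1.1-fold higher number from compound 1 to compound 2 (0.04 log units; within the scatter), did not show. The step is only a lower bound, and how far compound 4 lies past the limit cannot be read.

With just these two groups compared on this nitrogen, the compounds shown do not separate the effect of the identity of the halogens from that of where they sit on the ring. On these data alone, how a 3-ethynylphenyl or a 3-methoxyphenyl group would read at this position also remains open.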